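The source may hold more compounds than are shown below. What is called first, only, known or untested is meant among the compounds shown, and "the series" means these compounds.

Measured in a functional assay on PANC-1 cells (Homo sapiens) for inhibition, read by MTT assay, with a stated time of 24 h, tested at 10 uM (on this read-out lower numbers stand for less inhibition and higher numbers for more inhibition at the one concentration tested (going by the name of the read-out)), so far:
compound 1 `CC(C)=CCOc1cc(=O)n(CCCO)c2c1CC(CC=C(C)C)C(C)(C)C2` gives 20.7%
compound 2 `COc1cccc(NC(=O)Oc2cc(=O)n(CCCO)c3c2CC(CC=C(C)C)C(C)(C)C3)c1` gives 16.2%
compound 3 `CC(C)=CCC1Cc2c(OC(=O)Nc3ccccc3F)cc(=O)n(CCCO)c2CC1(C)C` gives 52.3%

Compound 3 stands highest of the three numbers. Its nearest neighbour is compound 1, with the gap a number 31.6 percentage points higher from compound 1 to compound 3 (beyond the scatter); the step of a number 36.1 percentage points higher from compound 2 to compound 3 (beyond the scatter) is larger still. The step from compound 1 to compound 2, a number 4.5 percentage points lower from compound 1 to compound 2 (within the scatter), stays within the scatter, so the two carbamates differ from each other mainly through the aryl group on the amide-type nitrogen.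

Compound 4 `CC(C)=CCC1Cc2c(OC(=O)Nc3ccc(F)c(F)c3)cc(=O)n(CCCO)c2CC1(C)C` is the next member. Its difference from compound 3 is 3,4-difluorophenyl in place of 2-fluorophenyl on an amide-type nitrogen.

Within the data shown here, the one measured step that bears on this change is a number 36.1 percentage points higher from compound 2 to compound 3 (beyond the scatter), where a swap of the aryl group on the amide-type nitrogen moved the read-out by a large amount. Among the measured compounds shown here, no measured pair tells how the number of fluorines or their placement on that ring matters, so the direction of the new step is open. Given that compound 3 is already the highest number, and that aryl swaps on this nitrogen have moved the read-out both ways relative to the scatter, a step downward or no step beyond the scatter is expected for compound 4, with an estimated step of a number 12.3 percentage points lower from compound 3 to compound 4 (beyond the scatter). Compound 4 is thus estimated at 40%, between 15% and 65%.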

Compound 4, a percentage reported as inhibition, at one concentration (the size of the read-out at that concentration, not a potency): 76.7%
For compound 4 the middle estimate is 36.7 percentage points below the measured one; the whole stated range lies below it.
By their numbers in this assay, from the lowest: compounds 2 and 1 (each within the scatter of the next); then compound 3; then compound 4.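

In this assay, the aryl group on the amide-type nitrogen can lift the number well past that of compound 3: 3,4-difluorophenyl in place of 2-fluorophenyl gives a number 24.4 percentage points higher from compound 3 to compound 4 (beyond the scatter), so 2-fluorophenyl does not mark the ceiling at this position. The same aryl group gives a number 60.5 percentage points higher from compound 2 to compound 4 (beyond the scatter) against 3-methoxyphenyl, and the full (3,4-difluorophenyl)carbamoyl group gives a number 56 percentage points higher from compound 1 to compound 4 (beyond the scatter) against 3-methylbut-2-en-1-yl on the oxygen on the aromatic ring, so both fluorinated carbamates stand above compound 1, while compound 2, the carbamate with 3-methoxyphenyl, goes against any general gain from the carbamate. No measurement on hand accounts for the higher number with 3,4-difluorophenyl.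

The compounds shown leave open whether the number of fluorines or their placement on the ring carries the step, a question that 3-fluorophenyl or 4-fluorophenyl on the same nitrogen would address. Going by these compounds, it is also open how other groups at this position would read, such as 3,4-dichlorophenyl or a saturated chain like cyclohexyl in place of the aromatic ring.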